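Ring amide nitrogen substituent: cyclopropyl after isopentyl

The source may report more compounds than this note shows. Statements on the series, on what has been measured and on what is new or still open speak of the compounds shown alone.

In an assay on HEK293 cells for positive allosteric modulation of metabotropic glutamate receptor 2 (Rattus norvegicus), read by thallium flux (on this read-out higher numbers stand for an effect only at larger amounts of compound and lower numbers for an effect already at smaller amounts), compound 2 `CC(C)CCN1Cc2cc(OCc3cccc(-c4ccc(Cl)c(C(=O)O)c4)c3)ccc2C1=O` gives 60 nM and compound 1 `CC(C)N1Cc2cc(OCc3cccc(-c4ccc(Cl)c(C(=O)O)c4)c3)ccc2C1=O` gives 70 nM, two numbers within the scatter of each other. Among the compounds with values here, the single step in hand, a 1.2-fold lower number from compound 1 to compound 2 (0.07 log units; within the scatter), bears on the same place. Compound 3 `O=C(O)c1cc(-c2cccc(COc3ccc4c(c3)CN(C3CC3)C4=O)c2)ccc1Cl` differs from compound 2 by cyclopropyl in place of isopentyl on an amide-type nitrogen in a ring. Because a 1.2-fold lower number from compound 1 to compound 2 (0.07 log units; within the scatter) stayed within the scatter for a change at this same nitrogen, no shift beyond the scatter is expected from the new group in this assay. Compound 3 is estimated at 80 nM, in the range 35 nM to 180 nM. The expected step of a 1.3-fold higher number from compound 2 to compound 3 (0.12 log units; within the scatter) lies within the scatter.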

Compound 3, half-maximal effective concentration: 220 nM
Beside the measured number, compound 3's estimate is 2.8-fold (0.44 log units) below it, and the stated range ends below it.
By their numbers in this assay, from the lowest: compounds 2 and 1 (each within the scatter of the next); then compound 3.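

The ring amide nitrogen is not indifferent to its substituent in this assay: cyclopropyl gives a 3.7-fold higher number from compound 2 to compound 3 (0.56 log units; beyond the scatter) and a 3.1-fold higher number from compound 1 to compound 3 (0.50 log units; beyond the scatter), both beyond the scatter. The agreement within the scatter between compound 1 and compound 2 therefore holds for isopropyl and isopentyl only and does not extend to cyclopropyl. No supporting data on hand bear on the reason for this step.

Compound 3 differs from compound 2 in both the ring and the carbon count of the substituent, so these two changes remain unseparated. Cyclopropylmethyl or cyclobutyl on the same nitrogen would help to tell them apart.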